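The source may report more compounds than this note shows. Statements on the series, on what has been measured and on what is new or still open speak of the compounds shown alone.

Compound 1 `COc1ccc(N)c(C(=O)CCNC(C)=O)c1` gives 30.7% in an assay for inhibition of Nitric oxide synthase, inducible (Homo sapiens), read by scintillation counting, with a stated time of 30 min, tested at 1 mM; on this read-out higher numbers stand for more inhibition at the one concentration tested (going by the name of the read-out) and lower numbers for less inhibition. Compound 2 `CCCCC(=O)NCCC(=O)c1cc(OC)ccc1N` gives 14.1% in the same assay.

Among the measured compounds shown here, compound 2 stands lowest of the two numbers; the only step known, a number 16.6 percentage points lower from compound 1 to compound 2 (beyond the scatter), shows that a longer chain on the acetyl side of the amide lowered the read-out. Compound 3 `COc1ccc(N)c(C(=O)CCNC(=O)C2CC2)c1` differs from compound 2 by cyclopropyl in place of butyl on a carbonyl carbon. This shortens the chain back toward compound 1 while keeping it larger than hydrogen, so compound 3 is expected to lie between the two, with a step of a number 7.9 percentage points higher from compound 2 to compound 3 (within the scatter) estimated, giving an expected value of 22%, in the range 8% to 38%.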

Compound 3, a percentage reported as inhibition, at one concentration (the size of the read-out at that concentration, not a potency): 2.66%
For compound 3 the middle estimate is 19.3 percentage points above the measured one, and the stated range ends above it.
By their numbers in this assay, from the lowest: compound 3; then compound 2; then compound 1.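

In this assay cyclopropyl on this carbonyl carbon gives the lowest number of the three, with a number 11.4 percentage points lower from compound 2 to compound 3 (beyond the scatter) and a number 28 percentage points lower from compound 1 to compound 3 (beyond the scatter) in the read-out. Replacing butyl with cyclopropyl removes one heavy atom and adds a three-membered ring, yet the number falls further, so these three compounds do not follow a simple order of group size. No measurement at hand explains this drop. On these data alone, whether the lower number belongs to the ring itself remains open, and a cyclohexyl group or an open-chain isopropyl group on this carbonyl carbon would bear on that. As far as these compounds go, how an amine at this place would read also remains open.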